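Ortho-Fluorine on the Isoxazole Aryl Group: Cytotoxicity Outlook

The source may report more compounds than this note shows. Statements on the series, on what has been measured and on what is new or still open speak of the compounds shown alone.

Compound 1 `O=[N+]([O-])c1ccc(CN2CCC(n3cc(CC(OCc4cc(-c5ccccc5)no4)c4ccc(Br)cc4)nn3)CC2)cc1`: 7000 nM
Compound 2 `N#Cc1ccc(-c2cc(COC(Cc3cn(C4CCN(Cc5ccc([N+](=O)[O-])cc5)CC4)nn3)c3ccc(Br)cc3)on2)cc1`: 5000 nM
Compound 3 `O=[N+]([O-])c1ccc(CN2CCC(n3cc(CC(OCc4cc(-c5ccccc5Br)no4)c4ccc(Br)cc4)nn3)CC2)cc1`: > 25000 nM

Of the compounds shown here, three sharing one core have been measured in a functional assay on Huh-7 cells (Homo sapiens) for cytotoxicity, with a stated time of 48 h; a lower number here means a stronger inhibitor, a higher number a weaker inhibitor. Compound 1 gives 7000 nM. Compound 2 gives 5000 nM, the lower of the two numbers, although a 1.4-fold lower number from compound 1 to compound 2 (0.15 log units; within the scatter), so no order can be read between them. For compound 3 this assay reports only a limit, > 25000 nM, which is the limit of > 25000 nM in this assay, at which 1 of the 3 values shown sits.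

Compound 4 `O=[N+]([O-])c1ccc(CN2CCC(n3cc(CC(OCc4cc(-c5ccccc5F)no4)c4ccc(Br)cc4)nn3)CC2)cc1` differs from compound 2 in one place: 2-fluorophenyl in place of 4-cyanophenyl on an aromatic carbon. Among the measured compounds shown here, two measured steps bear on this. The change from hydrogen to bromo on the same ring carbon gave an at least 3.5-fold higher number from compound 1 to compound 3 (0.55 log units; beyond the scatter), and the change from 4-cyanophenyl to 2-bromophenyl gave an at least 5.0-fold higher number from compound 2 to compound 3 (0.69 log units; beyond the scatter). Both point toward a higher number when a group sits in that position, so a step upward in this assay is expected from compound 2 to compound 4, estimated as a 3.0-fold higher number from compound 2 to compound 4 (0.48 log units; beyond the scatter). For compound 4 the estimated value is 15000 nM, expected to lie between 6000 nM and 40000 nM.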

Compound 4, half-maximal inhibitory concentration: 2000 nM
Compound 4: the middle estimate sits 7.5-fold (0.88 log units) above what was measured; measured number outside the range, below it.
By their numbers in this assay, from the lowest: compound 4; then compounds 2 and 1 (each within the scatter of the next). At a limit, above all of these: compound 3.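

In this assay, a group on the phenyl ring carried at this carbon of the five-membered aromatic ring does not by itself raise the number: fluoro in place of hydrogen gives a 3.5-fold lower number from compound 1 to compound 4 (0.54 log units; beyond the scatter), whereas bromo in place of hydrogen went the other way. Which atom is added therefore decides the direction, since fluoro in place of bromo gives an at least 12-fold lower number from compound 3 to compound 4 (1.09 log units; beyond the scatter), and 2-fluorophenyl also separates from 4-cyanophenyl, with a 2.5-fold lower number from compound 2 to compound 4 (0.40 log units; beyond the scatter). Compound 3 stands at a limit and not at a number: the limit of > 25000 nM in this assay, at which 1 of the 4 values shown sits.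

The compounds shown leave open whether the lower number belongs to fluoro alone or would also come with chloro, methoxy or an amine on that phenyl ring. They also leave open whether this order holds in cells other than those of this assay.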